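A few compounds are considered here, and "the series" means these few. Any claim that something is new, unique, unknown or untested is made for them only; others in the source may bear on it.

Measured so far in a functional assay on cells (Mus musculus) for antiproliferative activity, read by sulforhodamine B assay, with a stated time of 5 days; a higher number here means a weaker inhibitor, a lower number a stronger inhibitor:
Compound 1 `O=C(Nc1ccc(Cl)c(Cl)c1)Nc1ncccc1O` gives > 20000 nM, which is a limit of the assay and not a number.
Compound 2 `Cc1ccc(NC(=O)Nc2ccc(Cl)c(C(F)(F)F)c2)cc1O` gives > 20000 nM, again a limit of the assay.
Compound 3 `O=C(Nc1ccc(Cl)c(C(F)(F)F)c1)Nc1ncccc1O` gives 15400 nM.

Compound 2 thus stands at the limit of this assay, as does compound 1, a fact recorded as the limit of > 20000 nM in this assay, at which 2 of the 3 values shown sit. Compound 4 `COc1cc(NC(=O)Nc2ccc(Cl)c(C(F)(F)F)c2)ccc1C` differs from compound 2 by methyl in place of hydrogen on an oxygen on an aromatic ring. Within the data shown here, the only measured step, an at least 1.2-fold lower number from compound 1 to compound 3 (0.11 log units; that floor lies within the scatter), concerns a different group and does not bear on this change; no measured step informs it. Compound 4 is therefore expected near 25000 nM, with a range from 8000 nM to 80000 nM. That estimate means a step that the limit leaves unreadable from compound 2 to compound 4, nothing beyond the scatter, and most likely another limit.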

Compound 4, half-maximal inhibitory concentration: 18600 nM
Beside the measured number, compound 4's estimate is 1.3-fold (0.13 log units) above it; the measured number falls inside the stated range.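

In this assay, going from hydroxy to methoxy on the aromatic ring gives an at least 1.0-fold lower number from compound 2 to compound 4 (0.03 log units; that floor lies within the scatter). Compound 4 therefore shows that the hydrogen on this oxygen is not needed for a readable value, but compound 2 gives only a limit, so this cannot be called a gain. Comparisons in this series remain coarse: the limit of > 20000 nM in this assay, at which 2 of the 4 values shown sit.

On these data alone, it remains open how an amine in place of the hydroxy, or an ethoxy, would read. Also unknown is whether any change at this place can give a value well clear of that limit.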